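The compounds below may be only part of what the source reports. "The series", "measured", "known", "first", "only" and "open" are said of these compounds alone.

Three compounds have been measured in a functional assay for inhibition, with Homo sapiens as the target; a higher number here means weaker binding, a lower number tighter binding:
compound 1, `O=C(O)CC/C=C\CC1COC(c2cccnc2)OC1c1cccnc1`, gives 759 nM;
compound 2, `O=C(O)CC/C=C\CC1COC(c2ccc3ccccc3c2)OC1c1cccnc1`, gives 1780 nM;
compound 3, `CC(C)(Oc1ccc(F)cc1)C1OCC(C/C=C\CCC(=O)O)C(c2cccnc2)O1`, gives 120 nM.

Compound 3 has the lowest number of the three, and its gaps to compound 1 and to compound 2 both lie beyond the scatter. Compound 4, `CC(C)(Cc1ccc(F)cc1)C1OCC(C/C=C\CCC(=O)O)C(c2cccnc2)O1`, has not yet been measured. It differs from compound 3 in one place: 4-fluorobenzyl in place of 4-fluorophenoxy on a saturated chain carbon bound to two saturated chain carbons and a saturated ring carbon. Within the data shown here, the only measured step so far, a 2.3-fold higher number from compound 1 to compound 2 (0.37 log units; beyond the scatter), exchanges one aromatic ring for another on a saturated ring carbon. That change sits at a different position and is of a different kind, so it offers little guidance for the present step. Among the measured compounds shown here, with no closer precedent among the measured compounds, the expectation is a small step, within or close to the scatter, in either direction. For compound 4 the estimate in this assay is 150 nM, expected to fall within 50 nM to 450 nM. That estimate corresponds to an expected step of a 1.3-fold higher number from compound 3 to compound 4 (0.10 log units; within the scatter).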

Compound 4, dissociation constant: 89.1 nM
Compound 4: the middle estimate sits 1.7-fold (0.23 log units) above what was measured, and the stated range covers the measured number.
By their numbers in this assay, from the lowest: compounds 4 and 3 (each within the scatter of the next); then compound 1; then compound 2.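

In this assay putting 4-fluorobenzyl in place of 4-fluorophenoxy gives a 1.3-fold lower number from compound 3 to compound 4 (0.13 log units; within the scatter) and so leaves the two compounds level. On this saturated chain carbon, the hydrogen-bond acceptor counted in 4-fluorophenoxy, which 4-fluorobenzyl lacks, can therefore go without a step that this assay can resolve, something the earlier ring exchange on a saturated ring carbon could not show. No supporting measurement is available to explain why the two groups read alike.

The compounds shown leave open whether an amine in place of 4-fluorophenoxy, or a longer chain carrying the same fluorinated aromatic ring, would also stay level with compound 3. Both groups compared here carry fluorine, so they also leave open what a hydrogen or a chlorine in its place would give.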